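Working notes: methyl to bromo on the aromatic ring

This account rests on a few compounds, and the source may have more. Where it says the series, first, only, none or still open, it means among the compounds named here.

compound 1 (`S=C(N/N=C/c1cccs1)Nc1cccc2ccccc12`): > 100000 nM
compound 2 (`Cc1ccc(NC(=S)N/N=C/c2cccs2)cc1`): 16800 nM
compound 3 (`C=CCNC(=S)N/N=C/c1cccs1`): > 100000 nM

Going by the values given here, in a functional assay on UACC-62 cells (Homo sapiens) for inhibition, read by sulforhodamine B assay, with a stated time of 48 h (on this read-out higher numbers stand for weaker inhibition of growth and lower numbers for stronger inhibition of growth), compound 2 gives the only actual number of the series (16800 nM). Compound 1 at > 100000 nM is a limit, not a number. Compound 3 at > 100000 nM is also a limit.

Compound 4 (`S=C(N/N=C/c1cccs1)Nc1ccc(Br)cc1`) differs from compound 2 in one place (bromo in place of methyl on an aromatic carbon): bromo in place of methyl on an aromatic carbon. Among the compounds with values here, no measured pair shows this change, so the expectation rests on compound 2 at 16800 nM alone. A small shift toward stronger inhibition of growth is expected, possibly none beyond the scatter. The expected step of a 1.2-fold lower number from compound 2 to compound 4 (0.08 log units; within the scatter) is small. Compound 4 is estimated at 14000 nM with an expected range (5000 nM to 45000 nM).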

Compound 4, concentration for 50% growth inhibition: 71100 nM
Compound 4: the middle estimate sits 5.1-fold (0.71 log units) below what was measured; the measured number lies above the stated range.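

The position para to a large group on the aromatic ring responds to what it carries: bromo in place of methyl gives a 4.2-fold higher number from compound 2 to compound 4 (0.63 log units; beyond the scatter), toward weaker inhibition of growth, although one heavy atom simply replaces another. Compound 4 still reads as a number, so this change leaves the value short of the limit seen in this series: the limit of > 100000 nM in this assay, at which 2 of the 4 values shown sit.

From the compounds shown here alone, with a single pair, it stays open whether this step is specific to bromo or reflects something particular to methyl. Going by these compounds, how an amine, a methoxy group or a carboxylic acid at this position would read also remains open.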